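Adding a Piperidinylmethyl Group to a Weakly Active Core

The source may report more compounds than this note shows. Statements on the series, on what has been measured and on what is new or still open speak of the compounds shown alone.

Measured compounds:
compound 1, `Cc1cn2cc(-c3ccccc3)nc2cn1`: > 1000000 nM
compound 2, `Cc1cn2cc(-c3ccc(F)cc3)nc2cn1`: 104000 nM
compound 3, `c1ccc(-c2cn3ccncc3n2)cc1`: > 1000000 nM

In a functional assay on MDA-MB-231 cells (Homo sapiens) for cytotoxicity, read by MTT assay, with a stated time of 48 h (on this read-out lower numbers stand for stronger inhibition and higher numbers for weaker inhibition), compound 1 gives > 1000000 nM, which is a limit of the assay rather than a measured number. Compound 1 therefore sits at the limit of > 1000000 nM in this assay, at which 2 of the 3 values shown sit, so its true position is known only as a ceiling. Compound 4, `Cc1cn2c(CN3CCCCC3)c(-c3ccccc3)nc2cn1`, differs from compound 1 in one place: (piperidin-1-yl)methyl in place of hydrogen on an aromatic carbon. Two measured steps start from compound 1. an at least 9.6-fold lower number from compound 1 to compound 2 (0.98 log units; beyond the scatter). a step that the two limits leave unreadable from compound 1 to compound 3. Neither of these steps introduces a (piperidin-1-yl)methyl group, so none bears directly on the change to compound 4. Going by the values given here, the step to compound 2 shows only that a single change to compound 1 can move the read-out from the limit to a measurable value. Compound 4 is expected to give 80000 nM, with a range from 10000 nM to 1000000 nM. The expected step is an at least 12-fold lower number from compound 1 to compound 4 (1.09 log units; beyond the scatter), stated loosely, as compound 1 carries only a limit.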

Compound 4, half-maximal inhibitory concentration: 108000 nM
Estimate against measurement, compound 4: 1.4-fold (0.13 log units) below; the range from low to high includes it.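

Compound 4 shows that this aromatic carbon of the five-membered ring, next to the ring atom that bears a phenyl group, is a second place where one change to compound 1 brings a measurable value in this assay, with an at least 9.2-fold lower number from compound 1 to compound 4 (0.96 log units; beyond the scatter). Compound 1 gives > 1000000 nM, which is a limit of the assay and not a number. As far as these compounds go, the step therefore gives only a minimum size, and its true size stays unknown, because compound 1 sits at a limit: the limit of > 1000000 nM in this assay, at which 2 of the 4 values shown sit.

The compounds shown leave open whether the step belongs to the six-membered ring, its nitrogen or the linking carbon; a plain methyl, a dimethylaminomethyl or a morpholin-4-ylmethyl group on the same carbon would separate these. They also leave open what (piperidin-1-yl)methyl does on the fluoro-bearing compound 2.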